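The source may report more compounds than this note shows. Statements on the series, on what has been measured and on what is new or still open speak of the compounds shown alone.

Compound 1 `O=C(Nc1ccc(Cl)c(-c2nnc3c(Cl)cccn23)c1)c1c(F)cccc1Cl` was tested in a functional assay on AN3-CA cells (Homo sapiens) for antiproliferative activity, read by MTT assay, with a stated time of 72 h; on this read-out higher numbers stand for weaker inhibition and lower numbers for stronger inhibition. In this assay compound 1 gives only a limit, > 100000 nM, and not a number. Compound 2 `O=C(Nc1ccc(Cl)c(-c2nnc3c(Cl)cccn23)c1)c1cccnc1Cl` differs by carrying 2-chloropyridin-3-yl in place of 2-chloro-6-fluorophenyl on the carbonyl carbon. In this assay compound 2 likewise gives only a limit, > 100000 nM. The step that the two limits leave unreadable from compound 1 to compound 2 cannot be sized, since both values sit at the limit of > 100000 nM in this assay, at which 2 of the 2 values shown sit. Compound 2 thus stands at the limit of the assay, with no number of its own.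

Compound 3 `O=C(Nc1ccc(Cl)c(-c2nnc3c(Cl)cccn23)c1)c1ccccc1` is the next variation: phenyl in place of 2-chloropyridin-3-yl on a carbonyl carbon. Going by the values given here, the only measured step, that at the same carbonyl carbon, is unreadable, so it offers neither a direction nor a size for this change. The expected step is a number no higher from compound 2 to compound 3 (the limit leaves the size open), and compound 3 most likely also ends at the limit. Compound 3 is estimated at 100000 nM, within a range from 30000 nM to 300000 nM.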

Compound 3, half-maximal inhibitory concentration: 67600 nM
Beside the measured number, compound 3's estimate is 1.5-fold (0.17 log units) above it; the range from low to high includes it.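

In this assay, phenyl on the carbonyl carbon gives the first real number among the compounds shown, whereas the two rings carrying halogens gave only a limit: the limit of > 100000 nM in this assay, at which 2 of the 3 values shown sit.

Measured against those limits, the change is an at least 1.4-fold lower number from compound 2 to compound 3 (0.17 log units; that floor lies within the scatter), and the change from the other ring is an at least 1.4-fold lower number from compound 1 to compound 3 (0.17 log units; that floor lies within the scatter). Each figure is only a floor set by a limit, so the true gap may be larger, but the floor alone does not clear the usual scatter.

The compounds shown leave open whether the chlorine, the fluorine or the ring nitrogen matters most in separating compound 3 from compound 1 and compound 2. Also open, from the compounds shown here alone, is how this number would move with an amine or a carboxylic acid on the phenyl ring, or with a longer chain in its place.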